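This account rests on a few compounds, and the source may have more. Where it says the series, first, only, none or still open, it means among the compounds named here.

Measured compounds:
compound 1 `O=C(Nc1sc2c(c1C(=O)NNc1ccccc1)CCCCC2)NS(=O)(=O)c1ccccc1`, 15200 nM
compound 2 `O=C(Nc1sc2c(c1C(=O)NNc1ccc(Br)cc1)CCCCC2)NS(=O)(=O)c1ccccc1`, 10200 nM
compound 3 `O=C(Nc1sc2c(c1C(=O)NNc1ccc(Cl)cc1)CCCCC2)NS(=O)(=O)c1ccccc1`, 7500 nM

These values come from a functional assay on cells (Cancer cell lines, Homo sapiens) for inhibition, with a stated time of 48 h; a higher number here means a weaker inhibitor of growth, a lower number a stronger inhibitor of growth. Compound 2 sits between the other two, and both its neighbours lie within the scatter of it: compound 3 by a 1.4-fold lower number from compound 2 to compound 3 (0.13 log units; within the scatter), compound 1 by a 1.5-fold lower number from compound 1 to compound 2 (0.17 log units; within the scatter). Compound 4 `CCCNC(=O)c1c(NC(=O)NS(=O)(=O)c2ccccc2)sc2c1CCCCC2` differs from compound 2 by propyl in place of (4-bromophenyl)amino on an amide-type nitrogen. Going by the values given here, none of the measured steps touches this part of the shared core; they only swap hydrogen, bromo and chloro on the ring that is now removed, and those steps were small. Among the compounds with values here, no step therefore speaks directly to this change, and the expectation must rest on the narrow spread of the three values. The estimate for compound 4 in this assay is 20000 nM, between 5000 nM and 80000 nM, which is expected to be a step of a 2.0-fold higher number from compound 2 to compound 4 (0.29 log units; within the scatter).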

Compound 4, concentration for 50% growth inhibition: 76500 nM
The estimate for compound 4 lay 3.8-fold (0.58 log units) below the measured number, and the stated range covers the measured number.
By their numbers in this assay, from the lowest: compounds 3, 2 and 1 (each within the scatter of the next, the first and the last beyond it); then compound 4.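

Swapping hydrogen, bromo and chloro on the aromatic ring moved the number little, but replacing the whole group on the amide-type nitrogen costs more in this assay: a 7.5-fold higher number from compound 2 to compound 4 (0.88 log units; beyond the scatter), a 10-fold higher number from compound 3 to compound 4 (1.01 log units; beyond the scatter) and a 5.0-fold higher number from compound 1 to compound 4 (0.70 log units; beyond the scatter). Whichever of the three aryl groups leaves, propyl gives a weaker inhibitor of growth. No measurement shown explains this loss.

As far as these compounds go, the aromatic ring and the amino nitrogen leave together, so which one matters remains open. A benzyl group or a methylamino group on the amide-type nitrogen would separate the two.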